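The compounds below may be only part of what the source reports. "The series", "measured", "known", "first", "only" and "open" are said of these compounds alone.

Compound 3 `O=C1C(=O)N(CN(c2ccccc2)c2ccccc2)c2cccc(Br)c21` is measured in an ADME assay on 184B5 cells (Homo sapiens) for cytotoxicity, read by sulforhodamine B assay, with a stated time of 48 h (a lower number here means a stronger inhibitor of growth, a higher number a weaker inhibitor of growth), at 98500 nM, the second highest of the three numbers; compound 2 `CN(C)CN1C(=O)C(=O)c2c(Cl)cccc21`, at 130000 nM, lies within the scatter of it, while compound 1 `CCN(CC)CN1C(=O)C(=O)c2c(Cl)cccc21`, at 22500 nM, gives a lower number beyond the scatter. Compound 4 `O=C1C(=O)N(CN(c2ccccc2)c2ccccc2)c2ccccc21` differs from compound 3 by hydrogen in place of bromo on an aromatic carbon. Among the measured compounds shown here, the only measured step, a 5.8-fold higher number from compound 1 to compound 2 (0.76 log units; beyond the scatter), concerns the amine on the saturated chain carbon and so does not bear on a change at the aromatic ring; no step here tests the removal of a halogen. The expectation is therefore a step of a 1.0-fold higher number from compound 3 to compound 4 (0.01 log units; within the scatter), within the scatter. Compound 4 is expected to give about 100000 nM, between 40000 nM and 250000 nM.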

Compound 4, concentration for 50% growth inhibition: 33700 nM
For compound 4 the middle estimate is 3.0-fold (0.47 log units) above the measured one, and the stated range ends above it.
By their numbers in this assay, from the lowest: compounds 1 and 4 (each within the scatter of the next); then compounds 3 and 2 (each within the scatter of the next).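

Among the compounds shown here, the step of a 2.9-fold lower number from compound 3 to compound 4 (0.47 log units; beyond the scatter) in this assay shows that the read-out responds to a change on this aromatic carbon, and not only to the amine on the saturated chain carbon, the one place the earlier step touched. Here the compound carrying hydrogen, rather than bromo, is the stronger inhibitor of growth. Nothing measured alongside these compounds offers a reason for this step. As far as these compounds go, whether fluoro, methoxy or an amine on this carbon would track with bromo or with hydrogen remains open. So does whether the step holds with a diethylamino group on the chain.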